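Swapping the Aryl Group on the Triazole Nitrogen

The compounds below may be only part of what the source reports. "The series", "measured", "known", "first", "only" and "open" are said of these compounds alone.

Measured so far:
compound 1, `Oc1cc(C(F)(F)F)ccc1-c1nc(-c2ccccc2O)n(-c2ccc(Cl)cc2)n1`, in a functional assay on PC-12 cells (Rattus norvegicus) for cytotoxicity, read by MTT assay, with stated times of 2 h and 24 h, tested at 1 uM (a lower number here means a weaker effect, a higher number a stronger effect of the compound at the concentration tested), compound 1 gives 68%
compound 2, `COc1ccccc1-n1nc(-c2ccc(C(F)(F)F)cc2O)nc1-c1ccccc1O`, in this assay compound 2 gives 70.7%

Within the data shown here, compound 2 holds the higher of the two numbers, but its only neighbour, compound 1, sits within the scatter of it: the step of a number 2.7 percentage points higher from compound 1 to compound 2 (within the scatter) is too small to count as a real difference. Both compounds share the same core and differ only in the group on the aromatic nitrogen.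

Compound 3, `Oc1cc(C(F)(F)F)ccc1-c1nc(-c2ccccc2O)n(-c2ccc(Cl)cc2Cl)n1`, has not been measured. It differs from compound 2 in one place: 2,4-dichlorophenyl in place of 2-methoxyphenyl on an aromatic nitrogen. Among the measured compounds shown here, the only step on record that touches this position is the one from compound 1 to compound 2, which was within the scatter, so replacing one aryl group on that nitrogen by another has so far changed nothing measurable. The new group, 2,4-dichlorophenyl, resembles the 4-chlorophenyl of compound 1 more than the 2-methoxyphenyl of compound 2, and compound 1 gave 68%.

For that reason no step beyond the scatter is expected in this assay; the expected shift is a number 1.7 percentage points lower from compound 2 to compound 3 (within the scatter). Compound 3 is therefore estimated at 69%, with a range from 58% to 80%.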

Compound 3, a percentage reported as activity, at one concentration (the size of the read-out at that concentration, not a potency): 69%
For compound 3 middle estimate and measured number coincide at the digits printed; low and high end bracket the measured number.
By their numbers in this assay, from the lowest: compounds 1, 3 and 2 (each within the scatter of the next).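

In this assay a second pair of compounds now probes the group on the aromatic nitrogen, and the outcome is a number 1.7 percentage points lower from compound 2 to compound 3 (within the scatter) even though 2-methoxyphenyl and 2,4-dichlorophenyl are clearly different groups, one carrying oxygen and the other chlorine. The new compound also allows a smaller comparison at the same position, where chloro in place of hydrogen on an aromatic carbon of the aryl group gives a number 1 percentage points higher from compound 1 to compound 3 (within the scatter) and so leaves no measurable mark at the single concentration tested. Nothing measured alongside these numbers explains why the three aryl groups cannot be told apart here.

From the compounds shown here alone, all three compounds carry a six-membered aromatic ring on this nitrogen, so it remains open whether a small chain such as methyl, a cyclohexyl ring or a group bearing an amine or a carboxylic acid would also read within the scatter. The trifluoromethyl and hydroxyl groups are common to all three compounds, so these results cannot say how much those parts of the molecule contribute, or how the compounds would separate at other concentrations.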